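Swapping the amine linker for an ether in the carboxyphenyl arm

This account rests on a few compounds, and the source may have more. Where it says the series, first, only, none or still open, it means among the compounds named here.

Of the compounds shown here, three sharing one core have been measured in a functional assay on HEK293 cells for agonist activity at Bile acid receptor (Homo sapiens); a lower number here means that less compound is needed, a higher number that more compound is needed for the effect. Compound 1 `CC(C)c1onc(-c2c(Cl)cccc2Cl)c1COc1ccc(N(C)Cc2ccc(OCC(=O)O)cc2)c(C(F)(F)F)n1` gives 214 nM. Compound 2 `CC(Nc1ccc(C(=O)O)cc1)c1ccc(OCc2c(-c3c(Cl)cccc3Cl)noc2C2CC2)nc1C(F)(F)F` gives 333 nM, the highest of the three numbers, though its gap to compound 1 lies within the scatter. Compound 3 `CC(c1ccc(OCc2c(-c3c(Cl)cccc3Cl)noc2C2CC2)nc1C(F)(F)F)N(C)c1ccc(C(=O)O)cc1` gives 208 nM. For the measured compounds named here, the only single change among the measured compounds is the one from compound 2 to compound 3, where a methyl replaces a hydrogen on the nitrogen that joins the carboxyphenyl arm to the core; this gave a 1.6-fold lower number from compound 2 to compound 3 (0.20 log units; within the scatter).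

Compound 4 `O=C(O)c1ccc(OCc2ccc(OCc3c(-c4c(Cl)cccc4Cl)noc3C3CC3)nc2C(F)(F)F)cc1` is the next compound to be measured. Compared with compound 2, the change is (4-carboxyphenoxy)methyl in place of 1-((4-carboxyphenyl)amino)ethyl on an aromatic carbon. Going by the values given here, it touches the same linking region that the step from compound 2 to compound 3 altered, but it is a different kind of change, and no measured step reproduces it. Among the compounds with values here, the one step that bears on this region stayed within the scatter, so a similar outcome is expected here: for compound 4 the expected step is a 1.1-fold higher number from compound 2 to compound 4 (0.02 log units; within the scatter), with no direction beyond the scatter. The estimate for compound 4 in this assay is therefore 350 nM, within a range from 120 nM to 1000 nM.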

Compound 4, half-maximal effective concentration: 95 nM
Compound 4: the middle estimate sits 3.7-fold (0.57 log units) above what was measured; measured number below the stated range.
By their numbers in this assay, from the lowest: compound 4; then compounds 3, 1 and 2 (each within the scatter of the next).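

In this assay, replacing 1-((4-carboxyphenyl)amino)ethyl with (4-carboxyphenoxy)methyl on this aromatic carbon, ortho to the trifluoromethyl group, gives a 3.5-fold lower number from compound 2 to compound 4 (0.54 log units; beyond the scatter), a modest step but one beyond the scatter, whereas the earlier change in this linking region, a 1.6-fold lower number from compound 2 to compound 3 (0.20 log units; within the scatter), stayed within it. The linking region can therefore shift the number, which the methyl on the nitrogen alone did not show, but this swap changes more than one feature at once: the nitrogen and the methyl branch both leave, an oxygen enters, and the entering group has 1 hydrogen-bond donor where the leaving group has 2. No measurement offered here explains the shift.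

The compounds shown leave open whether the oxygen in place of the nitrogen or the loss of the methyl branch accounts for the step, or whether both contribute. A 1-(4-carboxyphenoxy)ethyl group, which pairs the oxygen with the branch, and a ((4-carboxyphenyl)amino)methyl group, which pairs the nitrogen with the unbranched chain, would each separate these two changes at this position.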